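A few compounds are considered here, and "the series" means these few. Any claim that something is new, unique, unknown or untested is made for them only; others in the source may bear on it.

Of the compounds shown here, three have numbers so far in a physicochemical assay for lipophilicity; a lower number here means a more polar compound, a higher number a more lipophilic compound: compound 1 `O=C(CN(C(=O)c1ccc(N2CCCC2)cc1)C1CCCCC1)Nc1cc(F)cc(F)c1` gives 4.5, compound 2 `O=C(CN(C(=O)c1ccc(-c2ccccn2)cc1)C1CCCOC1)Nc1cc(F)cc(F)c1` gives 2.7, and compound 3 `O=C(CN(CC1CCC1)C(=O)c1ccc(-c2ccccn2)cc1)Nc1cc(F)cc(F)c1` gives 3.5. Compound 3 therefore stands second of the three, lower than compound 1 and higher than compound 2.

Compound 4 `O=C(CN(C(=O)c1ccc(-c2ccccn2)cc1)C1CCOC1)Nc1cc(F)cc(F)c1` is not yet measured. The structural change is oxolan-3-yl in place of cyclobutylmethyl on an amide-type nitrogen, with oxolan-3-yl in place of cyclobutylmethyl on an amide-type nitrogen.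

Among the measured compounds shown here, only one measured step bears on this: a number 0.80 log units higher from compound 2 to compound 3 (beyond the scatter), a modest step beyond the scatter, with cyclobutylmethyl in place of oxan-3-yl. For the measured compounds named here, compound 1 differs in more than one place and gives no usable step. The change to compound 4 runs the opposite way, though with oxolan-3-yl rather than oxan-3-yl as the incoming group. On the evidence of a number 0.80 log units higher from compound 2 to compound 3 (beyond the scatter), a fall of similar or slightly larger size, beyond the scatter, is expected in this assay.

The expected change is a number 1.00 log units lower from compound 3 to compound 4 (beyond the scatter). For compound 4 the estimate is 2.5, with an expected range from 2.1 to 2.9.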

Compound 4, distribution coefficient: 2.5
For compound 4 middle estimate and measured number coincide at the digits printed; the range from low to high includes it.
By their numbers in this assay, from the lowest: compounds 4 and 2 (each within the scatter of the next); then compound 3; then compound 1.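

In this assay, oxolan-3-yl in place of cyclobutylmethyl on the amide-type nitrogen gives a number 1.00 log units lower from compound 3 to compound 4 (beyond the scatter) and so runs in the same direction as the reverse of the earlier step with oxan-3-yl, now seen with a second ring that holds one oxygen. The two oxygen-containing rings are not told apart at this position, with a number 0.20 log units lower from compound 2 to compound 4 (within the scatter) as the direct comparison between them. No measurement at hand gives a cause for either step.

On these data alone, compounds 2, 3 and 4 share one core, so it remains open whether these steps carry over to the core of compound 1, which differs in more than one place. Also open, as far as these compounds go, is how this assay responds at the same nitrogen to a group such as a tertiary amine, a carboxylic acid or a longer ether chain.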